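Diethylamino for dimethylamino on the propyl chain

A few compounds are considered here, and "the series" means these few. Any claim that something is new, unique, unknown or untested is made for them only; others in the source may bear on it.

Measured in a functional assay on PC-3 cells (Homo sapiens), read by MTT assay, with a stated time of 48 h; a higher number here means a weaker inhibitor, a lower number a stronger inhibitor:
- compound 1 `CCN(CC)CCCNC(=O)c1ccc(C(CC)(CC)c2ccc(OCC(=O)C(C)(C)C)c(C)c2)n1CC`: 1800 nM
- compound 2 `CCN(CC)CCNC(=O)c1ccc(C(CC)(CC)c2ccc(OCC(O)C(C)(C)C)c(C)c2)n1CC`: 220 nM
- compound 3 `CCn1c(C(=O)NCCCN(C)C)ccc1C(CC)(CC)c1ccc(OCC(O)C(C)(C)C)c(C)c1`: 3100 nM

Compound 3, at 3100 nM, lies within the scatter of compound 1 and well apart from compound 2. Compound 4 `CCN(CC)CCCNC(=O)c1ccc(C(CC)(CC)c2ccc(OCC(O)C(C)(C)C)c(C)c2)n1CC` differs from compound 3 in one place: diethylamino in place of dimethylamino on a saturated chain carbon, three bonds along the chain from an amide-type nitrogen. It carries diethylamino in place of dimethylamino on a saturated chain carbon, three bonds along the chain from an amide-type nitrogen. Within the data shown here, the one measured step that bears on this is a 14-fold higher number from compound 2 to compound 3 (1.15 log units; beyond the scatter), which also alters the chain, so only part of its size is expected to return here. A clear move to a lower number in this assay is expected, an estimated 5.2-fold lower number from compound 3 to compound 4 (0.71 log units; beyond the scatter). Compound 4 is estimated at 600 nM, with an expected range of 180 nM to 2000 nM.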

Compound 4, half-maximal inhibitory concentration: 2500 nM
Compound 4: middle estimate off by 4.2-fold (0.62 log units), on the low side; the whole stated range lies below it.
By their numbers in this assay, from the lowest: compound 2; then compounds 1, 4 and 3 (each within the scatter of the next).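

In this assay, diethylamino in place of dimethylamino on the propyl chain gives a 1.2-fold lower number from compound 3 to compound 4 (0.09 log units; within the scatter) and does not separate the two compounds, so this change alone carries no measurable weight here. Chain length does: going from 2-(diethylamino)ethyl to 3-(diethylamino)propyl gives an 11-fold higher number from compound 2 to compound 4 (1.06 log units; beyond the scatter) as the large step. On the propyl chain, 1-hydroxy-2,2-dimethylpropyl in place of (tert-butyl)carbonyl gives a 1.4-fold higher number from compound 1 to compound 4 (0.14 log units; within the scatter) and does not separate those compounds either. No supporting measurement accounts for these results.
Open, as far as these compounds go, is whether 2-(dimethylamino)ethyl matches 2-(diethylamino)ethyl on the shorter chain. Also open, from the compounds shown here alone, is how a longer chain, such as 4-(diethylamino)butyl, or a primary amine would read.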